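Ortho substitution on the anilide ring of the indole azobenzamide series

The source may hold more compounds than are shown below. What is called first, only, known or untested is meant among the compounds shown, and "the series" means these compounds.

Compound 1 `Cc1ccc(NC(=O)c2ccc(/N=N\c3c[nH]c4ccccc34)cc2)cc1` carries a 4-methylphenyl on the amide nitrogen and in a functional assay on P388 cells (Mus musculus) for inhibition, read by MTT assay, with a stated time of 72 h (a lower number here means a stronger inhibitor, a higher number a weaker inhibitor), compound 1 gives 300 nM. Compound 2 `Cc1cccc(NC(=O)c2ccc(/N=N\c3c[nH]c4ccccc34)cc2)c1C` differs only by a 2,3-dimethylphenyl in that place; in this assay compound 2 gives 51600 nM, and the step of a 170-fold higher number from compound 1 to compound 2 (2.24 log units; beyond the scatter) is large. Compound 3 `COc1ccccc1NC(=O)c1ccc(/N=N\c2c[nH]c3ccccc23)cc1` carries a 2-methoxyphenyl; in this assay compound 3 is reported as "not active" (no number reported), so no number places it on the scale, only that it stands far from compound 1. Compound 4 `O=C(Nc1ccccc1F)c1ccc(/N=N\c2c[nH]c3ccccc23)cc1` is the next member: fluoro in place of methoxy on an aromatic carbon, with fluoro in place of methoxy on an aromatic carbon, ortho to a large group. For the measured compounds named here, no measured step covers this exact exchange. Going by the values given here, the only quantified step, from compound 1 to compound 2, concerns a different pair of groups and bears on it just indirectly: within this set, both compounds that carry a group ortho to a large group, compound 2 and compound 3, are weak or without a number. Compound 4 keeps a group in that place, so a weak result is expected rather than a return toward compound 1. For compound 4 the value in this assay is estimated at 30000 nM, with a range from 3000 nM to 200000 nM, and a fair chance of no number at all.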

Compound 4, half-maximal inhibitory concentration: 106000 nM
Compound 4: the middle estimate sits 3.5-fold (0.55 log units) below what was measured; the measured number falls inside the stated range.
By their numbers in this assay, from the lowest: compound 1; then compound 2; then compound 4.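

In this assay the 2-fluorophenyl group, with its single heavy atom ortho to a large group, comes with a 350-fold higher number from compound 1 to compound 4 (2.55 log units; beyond the scatter) and so gives a measured number for a loss that compound 3 could only suggest without one. Taking the 2-fluorophenyl in place of the 2,3-dimethylphenyl gives a 2.1-fold higher number from compound 2 to compound 4 (0.31 log units; beyond the scatter) and brings no return toward compound 1, so within these compounds a small group in this place is no better tolerated than the two methyl groups; the change from methoxy to fluoro itself cannot be read as a step, as compound 3 has no number. No measurement in hand speaks to the cause of these rises.

The step from compound 1 to compound 4 changes both the group and where it sits, so these compounds do not separate the two contributions. Also open, on these data alone, is whether an amine or a carboxylic acid ortho to a large group would stay as weak as fluoro, or whether any group there could approach compound 1.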